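Removing the methoxy group from a selenium-bearing anilinoquinazoline analogue

A few compounds are considered here, and "the series" means these few. Any claim that something is new, unique, unknown or untested is made for them only; others in the source may bear on it.

Compound 1 `COc1ccc(CNc2nc([Se]C)nc3ccccc23)cc1` was examined in a functional assay on MCF7 cells (Homo sapiens) for cytotoxicity, read by MTT assay, with a stated time of 72 h (a lower number here means a stronger inhibitor of growth, a higher number a weaker inhibitor of growth), where compound 1 gives 42200 nM. Two related compounds were run alongside it. Compound 2 `COc1ccc(CNc2nc([SeH])nc3ccccc23)cc1` gives 42700 nM, and compound 3 `CCCCC[Se]c1nc([Se]CCCCC)c2ccccc2n1` gives 38400 nM; all three numbers sit close together, and compound 1 stands among them with no separation beyond the scatter. For the measured compounds named here, the one single-point step available, a 1.0-fold higher number from compound 1 to compound 2 (0.01 log units; within the scatter), concerns the selenium substituent and stays within the scatter.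

Compound 4 `C[Se]c1nc(NCc2ccccc2)c2ccccc2n1` differs from compound 1 at the benzylic ring: hydrogen in place of methoxy on an aromatic carbon. Going by the values given here, no measured pair in this set bears directly on that change; the only step available, from compound 1 to compound 2, lies elsewhere in the molecule and was flat. With nothing pointing in either direction, the expectation is that the change from compound 1 to compound 4 produces no shift beyond the scatter, so that a 1.1-fold lower number from compound 1 to compound 4 (0.02 log units; within the scatter) is expected. Compound 4 is therefore estimated to give 40000 nM, with an expected range from 20000 nM to 80000 nM.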

Compound 4, concentration for 50% growth inhibition: 15800 nM
Beside the measured number, compound 4's estimate is 2.5-fold (0.40 log units) above it; the whole stated range lies above it.
By their numbers in this assay, from the lowest: compound 4; then compounds 3, 1 and 2 (each within the scatter of the next).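

In this assay, for the compounds shown here, the aromatic carbon para to a large group is the first place in this set where a single change moves the number beyond the scatter: replacing methoxy with hydrogen gives a 2.7-fold lower number from compound 1 to compound 4 (0.43 log units; beyond the scatter). The change on selenium, by contrast, gave a 1.0-fold higher number from compound 1 to compound 2 (0.01 log units; within the scatter), so the flat step there said nothing about this position, where the methoxy group is not needed for growth inhibition and the bare ring does modestly better. Nothing available explains this gain.

As far as these compounds go, this rests on one pair, so it remains open whether a fluorine, a hydroxyl or a methyl at the same carbon would read like compound 1 or like compound 4. From the compounds shown here alone, it is also open whether the same step would appear with hydrogen on the selenium, as in compound 2.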